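Chloropyridinyl Amide Replaces the Ethylphenyl Amide

The compounds below may be only part of what the source reports. "The series", "measured", "known", "first", "only" and "open" are said of these compounds alone.

Three amides sharing one core have been measured in a functional assay on A549 cells (Homo sapiens) for antiproliferative activity, read by CCK-8 assay, with a stated time of 72 h; on this read-out lower numbers stand for stronger inhibition and higher numbers for weaker inhibition. Compound 1 `O=C(Nc1cccc(-c2oc3cc(-c4ccc(F)cc4)ccc3c(=O)c2O)c1)c1ccc(F)cc1` gives 6930 nM, compound 2 `O=C(Nc1cccc(-c2oc3cc(-c4ccc(F)cc4)ccc3c(=O)c2O)c1)c1ccc(F)cc1F` gives 20500 nM, and compound 3 `CCc1ccc(C(=O)Nc2cccc(-c3oc4cc(-c5ccc(F)cc5)ccc4c(=O)c3O)c2)cc1` gives 18500 nM. Compound 3 thus stands second highest of the three: its number is close to that of compound 2, as the step of a 1.1-fold lower number from compound 2 to compound 3 (0.04 log units; within the scatter) shows, and well above that of compound 1, as a 2.7-fold higher number from compound 1 to compound 3 (0.43 log units; beyond the scatter) shows. The two small changes on the amide aryl group, a 3.0-fold higher number from compound 1 to compound 2 (0.47 log units; beyond the scatter) and a 2.7-fold higher number from compound 1 to compound 3 (0.43 log units; beyond the scatter), both moved the number upward by a modest amount, while the exchange of the whole aryl group on the carbonyl carbon, a 1.1-fold lower number from compound 2 to compound 3 (0.04 log units; within the scatter), stayed within the scatter.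

Compound 4 `O=C(Nc1cccc(-c2oc3cc(-c4ccc(F)cc4)ccc3c(=O)c2O)c1)c1ccc(Cl)nc1` differs from compound 3 by 6-chloropyridin-3-yl in place of 4-ethylphenyl on a carbonyl carbon. Among the measured compounds shown here, no measured step covers this exchange directly; the closest precedents are the three above, where the aryl groups on the carbonyl carbon differed and the numbers spanned only a modest range. The step of a 1.9-fold lower number from compound 3 to compound 4 (0.27 log units; within the scatter) is therefore expected to stay within or near the edge of the scatter. Compound 4 is expected to give 10000 nM in this assay, with a range from 4000 nM to 25000 nM.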

Compound 4, half-maximal inhibitory concentration: 3580 nM
Compound 4: the middle estimate sits 2.8-fold (0.45 log units) above what was measured, outside the stated range (below it).
By their numbers in this assay, from the lowest: compounds 4 and 1 (each within the scatter of the next); then compounds 3 and 2 (each within the scatter of the next).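

In this assay, the earlier amides had shown only that changes on a benzene ring attached to the carbonyl carbon could raise the number, whereas the 6-chloropyridin-3-yl group shows that a ring with a hetero atom can stand here and give a clearly lower number than two of those amides: a 5.2-fold lower number from compound 3 to compound 4 (0.71 log units; beyond the scatter) and a 5.7-fold lower number from compound 2 to compound 4 (0.76 log units; beyond the scatter). Against the 4-fluorophenyl amide the picture differs, since a 1.9-fold lower number from compound 1 to compound 4 (0.29 log units; within the scatter) leaves compound 4 and compound 1 inseparable, so the four amides fall into two levels, with compound 1 and compound 4 on one and compound 2 and compound 3 on the other. Nothing among the data shown accounts for this grouping of the 6-chloropyridin-3-yl and 4-fluorophenyl amides apart from the 4-ethylphenyl and 2,4-difluorophenyl amides.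

As far as these compounds go, whether the ring nitrogen or the chlorine matters more for the step away from the 4-ethylphenyl amide stays open, and a 4-chlorophenyl amide or a plain pyridin-3-yl amide would separate the two. Also open, from the compounds shown here alone, is how an amine or a methoxy group in place of the chlorine on the same ring would read.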